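This account rests on a few compounds, and the source may have more. Where it says the series, first, only, none or still open, it means among the compounds named here.

Working notes on the series. Three compounds sharing one core have been run so far. Compound 1 `COc1ccc(/C=C/c2cc(OC)cc(OC)c2/C=C/C(=O)c2ccccc2C)cc1` gives 5.9 ug/mL in a functional assay on A549 cells (Homo sapiens) for antiproliferative activity, read by MTT assay, with a stated time of 48 h; a higher number here means a weaker inhibitor, a lower number a stronger inhibitor. Compound 2 `COc1ccc(/C=C/c2cc(OC)cc(OC)c2/C=C/C(=O)c2ccc(C)c(C)c2)cc1` gives 0.1 ug/mL in this assay. Compound 3 `COc1ccc(/C=C/c2cc(OC)cc(OC)c2/C=C/C(=O)c2ccc(Br)cc2)cc1` gives 8.3 ug/mL in this assay, the highest of the three numbers; the step of a 1.4-fold higher number from compound 1 to compound 3 (0.15 log units; within the scatter) lies within the scatter, while an 83-fold higher number from compound 2 to compound 3 (1.92 log units; beyond the scatter) is the one large gap. The other large step, a 59-fold lower number from compound 1 to compound 2 (1.77 log units; beyond the scatter), comes from exchanging the group on the carbonyl carbon.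

Compound 4 `COc1ccc(/C=C/c2cc(OC)cc(OC)c2/C=C/C(=O)c2ccc(Cl)cc2)cc1` is next; it differs from compound 3 by chloro in place of bromo on an aromatic carbon. Within the data shown here, no measured pair bears directly on this exchange: every step so far alters the whole group on the carbonyl carbon, not one halogen for another on the same ring. The large steps of compound 2 relate to 3,4-dimethylphenyl against the other groups and say nothing about bromo against chloro. Among the measured compounds shown here, with no precedent, the expected step of a 1.1-fold lower number from compound 3 to compound 4 (0.04 log units; within the scatter) is a small one, not beyond the scatter, in either direction. Compound 4 is therefore estimated at 7.5 ug/mL in this assay, with a range from 2.5 ug/mL to 22 ug/mL.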

Compound 4, half-maximal inhibitory concentration: 6.4 ug/mL
Estimate against measurement, compound 4: 1.2-fold (0.07 log units) above; low and high end bracket the measured number.
By their numbers in this assay, from the lowest: compound 2; then compounds 1, 4 and 3 (each within the scatter of the next).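

In this assay, among these compounds, the exchange of chloro for bromo on an aromatic carbon, para to a large group, gives the first direct reading of one halogen against another on this ring (a 1.3-fold lower number from compound 3 to compound 4 (0.11 log units; within the scatter)), and the two cannot be told apart here. The 4-chlorophenyl group also cannot be told apart from the 2-methylphenyl group (a 1.1-fold higher number from compound 1 to compound 4 (0.04 log units; within the scatter)), while the 3,4-dimethylphenyl group stays well apart from it (a 64-fold higher number from compound 2 to compound 4 (1.81 log units; beyond the scatter)), so compound 2 now stands separated by a large step from all three other compounds. Nothing on hand gives a reason for the lack of a halogen effect or for the large gap to compound 2.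

Still open, from the compounds shown here alone, is whether a fluoro, a methoxy or an amine in place of chloro on this aromatic carbon would stay with compounds 1, 3 and 4 or move toward compound 2 at 0.1 ug/mL in this read-out. Also open, going by these compounds, is whether a single methyl in place of chloro on this carbon would be enough to reach the low number of compound 2, or whether both methyl groups of the 3,4-dimethylphenyl group are needed.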